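The compounds below may be only part of what the source reports. "The series", "measured", "known", "first", "only" and "open" are said of these compounds alone.

In a functional assay on A-375 cells (Homo sapiens) for inhibition, read by CCK-8 assay, with a stated time of 72 h, tested at 2 uM (on this read-out higher numbers stand for more inhibition of growth at the one concentration tested and lower numbers for less inhibition of growth), compound 1 (`COc1ccc(SCc2ccc(C(=O)Nc3ccccc3N)cc2)cc1`) gives 10.2%. Compound 3 (`Nc1ccccc1NC(=O)/C=C/c1ccc(CSc2ccc(C(F)(F)F)cn2)cc1`) gives 10.3%, within the scatter of compound 1, and compound 2 (`Nc1ccccc1NC(=O)c1ccc(CSc2cccc(F)c2)cc1`) stands clear of both at 37.7%. Compound 1 therefore sits at the low end of the three numbers, level with compound 3.

Compound 4 (`CC(C)(C)c1ccc(SCc2ccc(C(=O)Nc3ccccc3N)cc2)cc1`) keeps the core of compound 1 and changes one group: tert-butyl in place of methoxy on an aromatic carbon In words, this is tert-butyl in place of methoxy on an aromatic carbon, para to a large group.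

For the measured compounds named here, one measured step bears on this change: a number 27.5 percentage points higher from compound 1 to compound 2 (beyond the scatter), with 3-fluorophenyl in place of 4-methoxyphenyl on a sulfur. Going by the values given here, that step also removes the methoxy group but brings in a different group, and no measured compound carries tert-butyl. Its size and direction therefore carry over only loosely. A small rise in this assay is expected, smaller than that step and possibly within the scatter. The estimated step is a number 5.8 percentage points higher from compound 1 to compound 4 (within the scatter). The value expected for compound 4 is 16%, with a range of 3% to 36%.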

Compound 4, percent growth inhibition at one concentration: 2.13%
Estimate against measurement, compound 4: 13.9 percentage points above; the measured number lies below the stated range.
By their numbers in this assay, from the lowest: compounds 4, 1 and 3 (each within the scatter of the next); then compound 2.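

In this assay, tert-butyl in place of methoxy on an aromatic carbon, para to a large group, gives a number 8.1 percentage points lower from compound 1 to compound 4 (within the scatter) and so produces no change beyond the scatter. Compound 4 also lacks the methoxy group, yet it does not repeat the rise seen in a number 27.5 percentage points higher from compound 1 to compound 2 (beyond the scatter) and so loss of methoxy alone does not go with a higher number in this pair of steps. No measurement shown gives a reason for this result.

As far as these compounds go, it remains open whether an amine or a carboxylic acid at this same place would move the number beyond the scatter from compound 1. The compounds shown also do not separate the effect of the fluorine in compound 2 from that of its place on the ring.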